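Swapping a Side Chain for a Third Aziridine Ring

This account rests on a few compounds, and the source may have more. Where it says the series, first, only, none or still open, it means among the compounds named here.

Of the compounds shown here, three on a shared core have been measured in a functional assay on L1210 cells (Mus musculus), with a stated time of 1 days; a lower number here means a less potent compound, a higher number a more potent compound, by a factor of ten per unit of this negative logarithm. Compound 1 `CC1=C(N2CC2)C(=O)C(CC(C)OC(N)=O)=C(N2CC2)C1=O` gives 5.86, compound 2 `COCCC1=C(N2CC2)C(=O)C(C)=C(N2CC2)C1=O` gives 5.19, and compound 3 `CC1=C(N2CC2)C(=O)C(CCCc2ccccc2)=C(N2CC2)C1=O` gives 3.93. Compound 2 thus stands second highest of the three: compound 1 sits a number 0.67 log units lower from compound 1 to compound 2 (beyond the scatter), while compound 3 sits a number 1.26 log units lower from compound 2 to compound 3 (beyond the scatter). The step of a number 1.93 log units lower from compound 1 to compound 3 (beyond the scatter) confirms that changes at this one position move potency a long way.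

Compound 4 `CC1=C(N2CC2)C(=O)C(N2CC2)=C(N2CC2)C1=O` has not yet been measured. It differs from compound 2 in one place: aziridin-1-yl in place of 2-methoxyethyl on a double-bonded ring carbon. Among the measured compounds shown here, no measured step replaces a chain with a ring of this kind, so none bears on it directly; the measured steps only show that this position is sensitive, with shifts of modest to large size in both directions from the middle. A step beyond the scatter is therefore expected, with the direction uncertain but leaning upward. Compound 4 is expected to give about 5.8, within a range from 4.8 to 6.8. For compound 4 this amounts to an expected a number 0.61 log units higher from compound 2 to compound 4 (beyond the scatter).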

Compound 4, logarithm of the reciprocal of the active concentration, log(1/C): 6.54
For compound 4 the middle estimate is 0.74 log units below the measured one; the range from low to high includes it.
By their numbers in this assay, from the lowest: compound 3; then compound 2; then compound 1; then compound 4.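

In this assay, placing aziridin-1-yl on this double-bonded ring carbon gives a number 1.35 log units higher from compound 2 to compound 4 (beyond the scatter), and the same swap gives a number 0.68 log units higher from compound 1 to compound 4 (beyond the scatter), so the gain holds against two different chains. The earlier compounds shown here showed only that changing the chain at this position could lower the number, whereas this result shows that a small three-membered ring, with fewer heavy atoms than either chain it replaces, can raise it past both. Nothing shown here explains the rise.

As far as these compounds go, it remains open whether the gain belongs to the aziridin-1-yl ring itself or would also appear with another group on this carbon, such as a simple amine or a carboxylic acid. A single example also cannot show how far the gain would carry over to other chains on the shared core.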